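A Methoxy for a Methyl on the Ketone Aryl Ring

A few compounds are considered here, and "the series" means these few. Any claim that something is new, unique, unknown or untested is made for them only; others in the source may bear on it.

Compound 1 `COc1cc(-c2nnc3n2NC(c2cccs2)C(C(=O)c2ccc(C)cc2)S3)cc(OC)c1OC` gives 12700 nM in a functional assay on A549 cells (Homo sapiens) for cytotoxicity, read by MTT assay, with a stated time of 48 h; a lower number here means a stronger inhibitor, a higher number a weaker inhibitor.
Compound 2 `COc1ccc(C(=O)C2Sc3nnc(-c4cc(OC)c(OC)c(OC)c4)n3NC2c2cccs2)cc1` gives only a limit, > 100000 nM, in this assay.
Compound 3 `COc1cc(-c2nnc3n2NC(c2ccco2)C(C(=O)c2ccc(C)cc2)S3)cc(OC)c1OC` gives only a limit, > 100000 nM, in this assay.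

For compound 3 the result in this assay is a limit, not a number, and it sits at the limit of > 100000 nM in this assay, at which 2 of the 3 values shown sit. Compound 4 `COc1cccc(C(=O)C2Sc3nnc(-c4cc(OC)c(OC)c(OC)c4)n3NC2c2ccco2)c1` differs from compound 3 by 3-methoxyphenyl in place of 4-methylphenyl on a carbonyl carbon. The measured step closest to this change is an at least 7.8-fold higher number from compound 1 to compound 2 (0.89 log units; beyond the scatter), where methoxy also replaced methyl on an aromatic carbon; the other step, an at least 7.8-fold higher number from compound 1 to compound 3 (0.89 log units; beyond the scatter), already carried the furan-2-yl to the limit. Neither step points to a lower number. Compound 4 is therefore expected to stay at the limit, so that a step that the limit leaves unreadable from compound 3 to compound 4 is expected to be none beyond the scatter. Compound 4 is estimated at 150000 nM, within 40000 nM to 600000 nM.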

Compound 4, half-maximal inhibitory concentration: > 100000 nM
Compound 4 was reported as a limit (the forecaster's own chance of this, stated with the estimate: 80%); the middle value is on the limit's open side.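

Compound 4, like compound 3, is reported only as a limit in this assay, so no step can be read between them. The compounds shown leave open whether 3-methoxyphenyl in place of 4-methylphenyl changes the result at all.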